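A (piperidin-1-yl)methyl group joins a limit-bound ester

A few compounds are considered here, and "the series" means these few. Any claim that something is new, unique, unknown or untested is made for them only; others in the source may bear on it.

In a functional assay on the whole organism with Rattus norvegicus as the target (on this read-out lower numbers stand for an effect already at smaller amounts and higher numbers for an effect only at larger amounts of compound), compound 1 (`CCOC(=O)C(=O)Nc1nc(-c2ccc3c(c2)OCCO3)cs1`) gives > 10 mg/kg as a limit, not a number. Compound 2 (`NC(=O)C(=O)Nc1nc(-c2ccc3c(c2)OCCO3)cs1`) gives > 30 mg/kg as a limit too. The measured step that the two limits leave unreadable from compound 1 to compound 2 therefore has no readable size, and it changes the ester, not the place at issue here. Compound 3 (`CCOC(=O)C(=O)Nc1nc(-c2ccc3c(c2)OCC(CN2CCCCC2)O3)cs1`) keeps that ester and differs from compound 1 by (piperidin-1-yl)methyl in place of hydrogen on a saturated ring carbon. Within the data shown here, no measured step bears on that place, so the expected step that the limit leaves unreadable from compound 1 to compound 3 is small and has no firm direction. In this assay compound 3 is expected near 15 mg/kg with an estimated range from 3 mg/kg to 80 mg/kg in repeated measurements.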

Compound 3, dose for half-maximal effect: > 10 mg/kg
Compound 3: only a limit was reported (the forecaster's own chance of this, stated with the estimate: 60%); the middle value does not contradict the limit.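

In this assay, among these compounds, compound 1 and compound 3 both give only a limit, not a number, so no step between them can be read. The compounds shown leave open whether (piperidin-1-yl)methyl in place of hydrogen changes the effect at all.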